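The compounds below may be only part of what the source reports. "The series", "measured", "known", "first", "only" and "open" are said of these compounds alone.

Of the compounds shown here, two have so far been measured in an assay on CHO cells for displacement of a labelled ligand from transient receptor potential cation channel subfamily V member 1 (Homo sapiens), read by scintillation counting, with a stated time of 60 min; on this read-out lower numbers stand for stronger inhibition and higher numbers for weaker inhibition. Compound 1, `CN(C)C1(Cc2ccccc2)CCN(c2cc(C(F)(F)F)ccc2CNC(=O)NCc2ccc(NS(C)(=O)=O)c(F)c2)CC1`, gives 266 nM in this assay. Compound 2, `CN(C)C1(Cc2ccccc2)CCN(c2cc(C(F)(F)F)ccc2CNC(=O)Nc2ccc3c(c2)OCC3)CC1`, gives 41.4 nM in this assay, the lower of the two numbers; the gap between compound 2 and compound 1 is beyond the scatter, so compound 2 shows the stronger inhibition of the pair. Compound 3, `CN(C)C1(Cc2ccccc2)CCN(c2cc(C(F)(F)F)ccc2CNC(=O)Nc2ccc3ccncc3c2)CC1`, has not yet been measured. It differs from compound 2 in one place: a group of 10 heavy atoms (9 carbon, 1 nitrogen; one six-membered aromatic ring of carbon only, one six-membered aromatic ring with 1 hetero atom) in place of a group of 9 heavy atoms (8 carbon, 1 oxygen; one five-membered non-aromatic ring with 1 hetero atom, one six-membered aromatic ring of carbon only), on an amide-type nitrogen, the new group sitting on an amide-type nitrogen whose other neighbour is a carbonyl carbon. For the measured compounds named here, no measured pair tells how this assay responds to such a swap, so the expectation rests only on compound 2. Since both groups are flat two-ring systems with one hetero atom and no donor, the step from compound 2 to compound 3 is expected to be small, a 1.4-fold higher number from compound 2 to compound 3 (0.16 log units; within the scatter), most likely not beyond the scatter. For compound 3 the estimate is 60 nM, with a range of 20 nM to 180 nM.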

Compound 3, inhibition constant: 7.33 nM
Compound 3: the middle estimate sits 8.2-fold (0.91 log units) above what was measured; measured number outside the range, below it.
By their numbers in this assay, from the lowest: compound 3; then compound 2; then compound 1.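

In this assay, isoquinolin-7-yl entering on the amide-type nitrogen in place of the group with the five-membered non-aromatic ring gives a 5.6-fold lower number from compound 2 to compound 3 (0.75 log units; beyond the scatter) at this place, the first step read here. As this step lies beyond the scatter, the place is sensitive to which two-ring group it carries, even though both groups have the same counts of hydrogen-bond donors and acceptors and no net charge. Nothing available explains the size of this step.

This single swap changes several features at once, so it leaves open whether the ring nitrogen itself matters, which a naphthalen-2-yl group would help to test. A quinolin-6-yl group could likewise show whether the position of that nitrogen matters.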